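The compounds below may be only part of what the source reports. "The series", "measured", "known", "first", "only" and "open" are said of these compounds alone.

Of the compounds shown here, three that share a common core have so far been tested in a functional assay on DU-145 cells (Homo sapiens) for inhibition, read by trypan blue exclusion, with a stated time of 96 h; a lower number here means a stronger inhibitor of growth, a higher number a weaker inhibitor of growth. Compound 3 `O=C(O)c1ccc(C(=O)/C(=C\c2ccc(Cl)c([N+](=O)[O-])c2)SCc2ccc(Cl)cc2Cl)cc1` gives 1000 nM. Compound 1 `O=C(O)c1ccc(C(=O)/C(=C\c2ccc(Br)c([N+](=O)[O-])c2)SCc2ccc(Br)cc2)cc1` gives 1000 nM, and compound 2 `O=C(O)c1ccc(C(=O)/C(=C\c2ccc(F)c([N+](=O)[O-])c2)SCc2ccc(Cl)cc2Cl)cc1` gives 1000 nM, so compound 3 stands level with both of them within the usual scatter of repeated measurements.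

Compound 4 `O=C(O)c1ccc(C(=O)/C(=C\c2ccc(Br)c([N+](=O)[O-])c2)SCc2ccc(Cl)cc2Cl)cc1` is the next compound to consider. It differs from compound 3 in a single place: bromo in place of chloro on an aromatic carbon. For the measured compounds named here, one measured step bears directly on a change of this kind. Going from compound 2 to compound 3 also exchanged one halogen for another on an aromatic carbon of the same ring, and that step gave no change at the digits printed from compound 2 to compound 3 (within the scatter). Compound 1 already carries the 4-bromo-3-nitrophenyl group, though attached to a core with a different sulfur-linked part, and its value matches that of compound 3 at the digits shown. Neither observation suggests a shift beyond the scatter.

The step of no change at the digits printed from compound 3 to compound 4 (within the scatter) is therefore expected to amount to no change. Compound 4 is estimated to give 1000 nM in this assay, with a likely range from 500 nM to 2000 nM.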

Compound 4, concentration for 50% growth inhibition: 1000 nM
Estimate against measurement, compound 4: no gap at the digits printed, and the stated range covers the measured number.
By their numbers in this assay, from the lowest: compounds 1, 2, 3 and 4 (each within the scatter of the next).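

In this assay, the halogen ortho to the nitro group can now be read as bromo as well, and exchanging chloro for bromo there gives no change at the digits printed from compound 3 to compound 4 (within the scatter) in the growth read-out. Fluoro and bromo can also be compared directly at this position, with no change at the digits printed from compound 2 to compound 4 (within the scatter), so the three halogens shown here read alike on this core. For the compounds shown here, the 4-bromo-3-nitrophenyl group also allows the first single-place comparison of the sulfur-linked part, since 2,4-dichlorophenyl in place of 4-bromophenyl gives no change at the digits printed from compound 1 to compound 4 (within the scatter), whereas compound 1 differed from compound 2 and compound 3 in more than one place.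

Nothing available here explains why these values coincide. Every compound shown keeps a halogen ortho to the nitro group and the same carboxylic acid on the shared core, so it remains open what a plain hydrogen, a methoxy group or an amine at that position would give, or what an ester or amide in place of the carboxylic acid would give.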